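Chain in place of ring on the shared core

The source may report more compounds than this note shows. Statements on the series, on what has been measured and on what is new or still open speak of the compounds shown alone.

For the measured compounds named here, in an assay for inhibition of Fatty-acid amide hydrolase 1 (Rattus norvegicus), using a Dixon plot (on this read-out lower numbers stand for stronger inhibition and higher numbers for weaker inhibition), compound 2 `CSCc1ccc(-c2cnc(C(=O)CCCCCCc3ccccc3)o2)nc1` gives 11.1 nM, the higher of the two numbers so far, though compound 1 `COCOCc1ccc(-c2cnc(C(=O)CCCCCCc3ccccc3)o2)nc1` at 10.1 nM lies within the scatter of it. Going by the values given here, the one measured step, a 1.1-fold higher number from compound 1 to compound 2 (0.04 log units; within the scatter), alters only the group on the saturated chain carbon bound to an aromatic carbon and bears little on the change now considered. Compound 3 `COCOCCCCCc1cnc(C(=O)CCCCCCc2ccccc2)o1` differs from compound 2 thus: a group of 9 heavy atoms (7 carbon, 2 oxygen; no ring) in place of a group of 9 heavy atoms (7 carbon, 1 nitrogen, 1 sulfur; one six-membered aromatic ring with 1 hetero atom), on an aromatic carbon. Among the compounds with values here, no measured step removes the ring, so the direction rests on judgment; a step of a 2.3-fold higher number from compound 2 to compound 3 (0.35 log units; beyond the scatter) toward a weaker number is expected, with a wide range. Compound 3 is estimated at 25 nM, between 8 nM and 80 nM.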

Compound 3, inhibition constant: 24.1 nM
Beside the measured number, compound 3's estimate is 1.0-fold (0.02 log units) above it, within the range that was stated.
By their numbers in this assay, from the lowest: compounds 1 and 2 (each within the scatter of the next); then compound 3.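

Replacing the ring-bearing group with the open chain gives a 2.2-fold higher number from compound 2 to compound 3 (0.34 log units; beyond the scatter) in this assay, so the six-membered aromatic ring is not required for inhibition at this position, although the modest step favours compound 2. The two groups have the same heavy-atom and hydrogen-bond acceptor counts, so the step does not follow a change in either count. Nothing available explains the difference.

Open, going by these compounds, is whether a phenyl ring would match compound 2, which would test the need for the ring nitrogen. On these data alone, the effect of a shorter chain, or of an amine at the chain end, also remains open.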